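The source may report more compounds than this note shows. Statements on the series, on what has been measured and on what is new or still open speak of the compounds shown alone.

Measured so far in a functional assay on NCI-H1581 cells (Homo sapiens) for inhibition, read by MTT assay, with a stated time of 48 h, tested at 10 uM; a lower number here means less inhibition, a higher number more inhibition at the concentration tested (going by the name of the read-out):
compound 1 `Cc1ccc(Nc2cc(NC(=O)Nc3c(Cl)cccc3Cl)ncn2)cc1F` gives 45.3%
compound 2 `COc1cc(NC(=O)Nc2cc(Nc3ccc(C)c(F)c3)ncn2)cc(OC)c1` gives 38%
compound 3 `CC(C)(C)c1ccc(Nc2cc(NC(=O)Nc3c(Cl)cccc3Cl)ncn2)cc1` gives 71.3%

Compound 2 has the lowest of the three numbers. Closest to it stands compound 1, whose number is higher by an amount within the usual scatter, so no order between these two is claimed. Furthest stands compound 3, whose number is higher by an amount beyond the scatter.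

Compound 4 `COc1cc(NC(=O)Nc2cc(Nc3ccc(C)c(C)c3)ncn2)cc(OC)c1` is not yet measured. It differs from compound 2 in one place: methyl in place of fluoro on an aromatic carbon. One heavy atom leaves and one heavy atom enters, with no change in ring count, donors, acceptors or charge. For the measured compounds named here, no step between measured compounds resembles this swap, so nothing measured sets its size. In this assay a step no larger than the scatter is expected, in either direction. Compound 4 is therefore expected to give about 42%, in a range from 25% to 60%. The estimated step is a number 4 percentage points higher from compound 2 to compound 4 (within the scatter), expected to stay within the scatter.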

Compound 4, a percentage reported as inhibition, at one concentration (the size of the read-out at that concentration, not a potency): 20.1%
Compound 4: the middle estimate sits 21.9 percentage points above what was measured; the measured number lies below the stated range.
By their numbers in this assay, from the lowest: compound 4; then compounds 2 and 1 (each within the scatter of the next); then compound 3.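

Going from 3-fluoro-4-methylphenyl to 3,4-dimethylphenyl gives a number 17.9 percentage points lower from compound 2 to compound 4 (beyond the scatter) in this assay. This position, ortho to a methyl group and meta to a large group, is therefore sensitive to a single heavy-atom exchange, even with no change in ring count, donors, acceptors or charge. No measurement at hand bears on the reason for this step.

Going by these compounds, whether an amine or a nitrile at this position would stay with compound 2 or fall further remains open. The same swap on the other side of the molecule, as in compound 1, also remains untested in the compounds shown.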